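This account rests on a few compounds, and the source may have more. Where it says the series, first, only, none or still open, it means among the compounds named here.

In a functional assay on LNCaP cells (Homo sapiens) for antiproliferative activity, read by MTT assay, with a stated time of 96 h (on this read-out higher numbers stand for weaker inhibition and lower numbers for stronger inhibition), compound 1 (`FC(F)(F)Oc1cccc(Nc2nnnc3ccc(N4CCNCC4)nc23)c1`) gives 8510 nM and compound 2 (`FC(F)(F)Oc1cccc(Nc2nnnc3ccc(Cl)nc23)c1`) gives 8620 nM, two values within the scatter of each other. Compound 3 (`OCCNc1ccc2nnnc(Nc3cccc(OC(F)(F)F)c3)c2n1`) has (2-hydroxyethyl)amino in place of chloro on an aromatic carbon. Going by the values given here, the only measured step at this same carbon, a 1.0-fold higher number from compound 1 to compound 2 (0.01 log units; within the scatter), exchanges piperazin-1-yl for chloro, so one measured exchange offers no support for a change beyond the scatter in this assay. The expected step is a 1.1-fold lower number from compound 2 to compound 3 (0.06 log units; within the scatter). For compound 3, the estimated value is 7500 nM, with an expected range of 2500 nM to 20000 nM.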

Compound 3, half-maximal inhibitory concentration: 42900 nM
Beside the measured number, compound 3's estimate is 5.7-fold (0.76 log units) below it, outside the stated range (above it).
By their numbers in this assay, from the lowest: compounds 1 and 2 (each within the scatter of the next); then compound 3.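

In this assay this aromatic carbon is not indifferent to its substituent: the exchange for (2-hydroxyethyl)amino gives a 5.0-fold higher number from compound 2 to compound 3 (0.70 log units; beyond the scatter) and, against the piperazin-1-yl compound, a 5.0-fold higher number from compound 1 to compound 3 (0.70 log units; beyond the scatter) in the same direction. Compounds 1 and 2 alone, within the scatter of each other, showed no such sensitivity, and compound 3 now gives the weakest inhibition of the three. Nothing measured here accounts for this step. Open, on these data alone, is whether the hydroxyl or the chain itself goes with the higher number, which an ethylamino, a 2-methoxyethylamino or a longer 3-hydroxypropylamino group at this carbon would separate.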